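Fluoro on the aryl piperazine ring of compound 2

The source may report more compounds than this note shows. Statements on the series, on what has been measured and on what is new or still open speak of the compounds shown alone.

In a functional assay on HCT-116 cells (Homo sapiens) for antiproliferative activity, read by sulforhodamine B assay (a higher number here means a weaker inhibitor, a lower number a stronger inhibitor), compound 1 (`CN1CCN(c2ccc(N/C=C3\C(=O)NC(=O)c4ccc(-n5cccc5)cc43)cc2)CC1`) gives 1500 nM and compound 2 (`CN1CCN(c2ccc(N/C=C3\C(=O)NC(=O)c4ccc(-c5ccoc5)cc43)cc2)CC1`) gives 1200 nM. Among the measured compounds shown here, these are the only two numbers so far, and they lie within the scatter of each other, so compound 2 stands level with compound 1.

Compound 3 (`CN1CCN(c2ccc(N/C=C3\C(=O)NC(=O)c4ccc(-c5ccoc5)cc43)cc2F)CC1`) is compound 2 with fluoro in place of hydrogen on an aromatic carbon. This is fluoro in place of hydrogen on an aromatic carbon of a six-membered aromatic ring of carbon only, ortho to a 4-methylpiperazin-1-yl group.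

For the measured compounds named here, the one measured step is a 1.3-fold lower number from compound 1 to compound 2 (0.10 log units; within the scatter). It exchanges 1H-pyrrol-1-yl for furan-3-yl at another place, so it bears on this change only indirectly, as a sign that one substitution left this assay unmoved. Going by the values given here, no measured pair covers a fluoro change, and the data give no direction for it. The expectation is therefore no shift beyond the scatter, with an estimated 1.1-fold lower number from compound 2 to compound 3 (0.04 log units; within the scatter). For compound 3 the estimated value is 1100 nM, with an expected range of 500 nM to 2400 nM.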

Compound 3, half-maximal inhibitory concentration: 2200 nM
Compound 3: middle estimate off by 2.0-fold (0.30 log units), on the low side; measured number inside the range.
By their numbers in this assay, from the lowest: compounds 2, 1 and 3 (each within the scatter of the next).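

In this assay, fluoro in place of hydrogen on an aromatic carbon ortho to a 4-methylpiperazin-1-yl group gives a 1.8-fold higher number from compound 2 to compound 3 (0.26 log units; within the scatter) and so leaves the number within the scatter. Among the compounds shown here, this is the first reading on the ring that carries the 4-methylpiperazin-1-yl group, since the earlier step, furan-3-yl in place of 1H-pyrrol-1-yl, lay at another place; a second single-place change has now stayed within the scatter, at a carbon that accepts one fluorine atom without a readable shift. The compounds shown offer no measured property that bears on this result, and the size of the step stays without an explanation.

On these data alone, a single fluorine atom is a small probe, so it remains open whether the same carbon would stay within the scatter with chloro, methoxy, an amine or a carboxylic acid in place of hydrogen. Also open, as far as these compounds go, is whether fluoro would read the same on the other carbons of this ring, and whether the step would hold with 1H-pyrrol-1-yl in place of furan-3-yl.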